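Carboxy exchanged for methanesulfonamido on the chain

The source may report more compounds than this note shows. Statements on the series, on what has been measured and on what is new or still open speak of the compounds shown alone.

Measured so far in an assay on cells for agonist activity at Bombesin receptor subtype-3 (Mus musculus), read by HTRF and inositol phosphate accumulation, with a stated time of 1 h; on this read-out higher numbers stand for an effect only at larger amounts of compound and lower numbers for an effect already at smaller amounts:
compound 1 `COC(=O)c1c(F)cccc1-c1ccc(CCc2ncc(CC(C)(C)C)n2CCC(=O)O)cc1`: 3 nM
compound 2 `CC(C)(C)Cc1cnc(CCc2ccc(-c3cccc(F)c3C(=O)O)cc2)n1CCC(=O)O`: 61 nM

Compound 2 stands highest of the two numbers; its nearest neighbour is compound 1, and the step of a 20-fold higher number from compound 1 to compound 2 (1.31 log units; beyond the scatter) is beyond the scatter. Compound 3 `CC(C)(C)Cc1cnc(CCc2ccc(-c3cccc(F)c3C(=O)O)cc2)n1CCNS(C)(=O)=O` has not yet been measured in this assay. It differs from compound 2 by methanesulfonamido in place of carboxy on a saturated chain carbon, two bonds along the chain from an aromatic nitrogen. Going by the values given here, no measured step covers this exchange: the only step known, a 20-fold higher number from compound 1 to compound 2 (1.31 log units; beyond the scatter), alters the same carboxy group by hydrogen in place of methyl on its oxygen, and it shows that a change of this group can move the number substantially. Whether methanesulfonamido in compound 3 reads more like the acid of compound 2 or not cannot be settled from two compounds, so the expected step of a 1.6-fold higher number from compound 2 to compound 3 (0.21 log units; within the scatter) is given with a wide range. The number expected for compound 3 is 100 nM, between 15 nM and 700 nM.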

Compound 3, half-maximal effective concentration: 4 nM
Compound 3: middle estimate off by 25-fold (1.40 log units), on the high side, and the stated range ends above it.
By their numbers in this assay, from the lowest: compounds 1 and 3 (each within the scatter of the next); then compound 2.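

In this assay, methanesulfonamido in place of carboxy gives a 15-fold lower number from compound 2 to compound 3 (1.18 log units; beyond the scatter), so a carboxy group on this saturated chain carbon is not required for a low number here. Going by these compounds alone, the earlier step left this chain carboxy untouched, and only this exchange shows that the 2-carboxyethyl group can be altered and that the number can fall when it is. Nothing measured here accounts for the size or direction of this step.

As far as these compounds go, it remains open whether the lower number is particular to methanesulfonamido or would also be seen with an amine, a primary amide or a tetrazole on the same chain, or with a longer chain. From the compounds shown here alone, it is also open whether the exchange would have a similar effect alongside the methyl ester of compound 1.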